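Cytotoxicity limit across the series, compound 3 to compound 4

The source may hold more compounds than are shown below. What is called first, only, known or untested is meant among the compounds shown, and "the series" means these compounds.

In an ADME assay on MDCK cells (Canis lupus familiaris) for cytotoxicity (a lower number here means that less compound is tolerated, a higher number that more compound is tolerated), compound 1 `CC(=O)Nc1ccc2oc(-c3ccnc(C(=O)N4CCC5(CC4)CCN(C(c4ccccc4)c4nnn(C)n4)CC5)c3)nc2c1` gives > 50000 nM as a limit of the assay. Compound 2 `CC(=O)Nc1ccc2oc(-c3ccnc(C(=O)N4CCC5(CC4)CN(C(c4ccccc4)c4nnn(C)n4)C5)c3)nc2c1` gives > 50000 nM as a limit too. Compound 3 `CC(=O)Nc1ccc2oc(-c3ccnc(C(=O)N4CCN(C(c5cccc(F)c5)c5nnn(C)n5)CC4)c3)nc2c1` also gives > 50000 nM as a limit. Among the compounds with values here, compound 3 thus has only a limit and no number, like the other two, and no step between measured compounds is available.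

Compound 4 `CC(=O)Nc1ccc2oc(-c3ccnc(C(=O)N4CCN(C(c5ccc(OC(F)(F)F)cc5)c5nnn(C)n5)CC4)c3)nc2c1` differs from compound 3 by 4-(trifluoromethoxy)phenyl in place of 3-fluorophenyl on a saturated chain carbon bound to an amine nitrogen in a ring and an aromatic carbon.

No change beyond the scatter is expected in this assay because the limit of > 50000 nM in this assay, at which 3 of the 3 values shown sit, covers compound 1, compound 2 and compound 3 alike. The expected step is a number no higher from compound 3 to compound 4 (the limit leaves the size open) and it is estimated to stay within the scatter. Compound 4 is estimated at 50000 nM with an expected range from 20000 nM to 100000 nM and a limit is the expected form of the result.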

Compound 4, half-maximal cytotoxic concentration: > 50000 nM
Compound 4 gave a limit, no number; the forecaster's own chance of this, stated with the estimate: 85%; the middle value lies on the limit itself.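

Within the data shown here, no step from compound 3 to compound 4 can be read in this assay: both results are limits, not numbers. The compounds shown leave open whether 4-(trifluoromethoxy)phenyl in place of 3-fluorophenyl changes the tolerated concentration at all, and one limit holds for the whole set: the limit of > 50000 nM in this assay, at which 4 of the 4 values shown sit.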